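A few compounds are considered here, and "the series" means these few. Any claim that something is new, unique, unknown or untested is made for them only; others in the source may bear on it.

In an assay on isolated protein for inhibition of Fatty-acid amide hydrolase 1 (Homo sapiens) (a lower number here means a stronger inhibitor, a higher number a weaker inhibitor), compound 1 `O=C(CCCC1CCN(C(=O)CCc2ccccc2)CC1)c1ncco1` gives 22 nM, and compound 2 `O=C(CCCC1CCN(C(=O)C2CCCCC2)CC1)c1ncco1` gives 45 nM. Among the compounds with values here, compound 2 thus stands at the higher of the two numbers; the one step between them is a 2.0-fold higher number from compound 1 to compound 2 (0.31 log units; beyond the scatter). Compound 3 `O=C(CCCC1CCN(Cc2ccccc2)CC1)c1ncco1` has not been measured. It differs from compound 2 in one place: benzyl in place of cyclohexylcarbonyl on an amine nitrogen in a ring. The entering group brings no hydrogen-bond acceptor where the leaving group had one. Within the data shown here, no measured step bears on this change directly: the single known step keeps the carbonyl and only swaps the group attached to it, so it offers little guidance. With the carbonyl itself gone, the expected outcome for compound 3 is a modestly higher number, carrying wide uncertainty, and the expected step is a 3.3-fold higher number from compound 2 to compound 3 (0.52 log units; beyond the scatter). The estimate for compound 3 is therefore 150 nM, within the expected range 40 nM to 600 nM.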

Compound 3, half-maximal inhibitory concentration: 315 nM
For compound 3 the middle estimate is 2.1-fold (0.32 log units) below the measured one; measured number inside the range.
By their numbers in this assay, from the lowest: compound 1; then compound 2; then compound 3.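

In this assay, putting benzyl in place of cyclohexylcarbonyl on the ring nitrogen gives a 7.0-fold higher number from compound 2 to compound 3 (0.85 log units; beyond the scatter), so this position is sensitive to more than which group sits on a retained carbonyl. The earlier change, with a 2.0-fold higher number from compound 1 to compound 2 (0.31 log units; beyond the scatter), kept that carbonyl, whereas this one removes it along with the leaving group's hydrogen-bond acceptor and also turns a non-aromatic ring into an aromatic one. No measurement here explains the rise in the number.

The two changes made at once in compound 3 therefore cannot be told apart. Cyclohexylmethyl on the same nitrogen would drop the carbonyl but keep the non-aromatic ring, while benzoyl would keep the carbonyl and carry an aromatic ring, and these two groups could show how much each change contributes.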